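The compounds below may be only part of what the source reports. "The series", "measured", "known", "first", "only" and "open" are said of these compounds alone.

Compound 1, `NC(=O)c1cc(Cl)c2c(Cl)c(C#CC3COCCO3)n([C@H]3CCCNC3)c2n1`, gives 77 nM; 203 nM (2 entries) in a functional assay on KG-1 cells (Homo sapiens) for antiproliferative activity; a higher number here means that more compound is needed for the effect, a lower number that less compound is needed.
Compound 2, `NC(=O)c1cc(Cl)c2c(Cl)c(C#CC3CCCO3)n([C@H]3CCCNC3)c2n1`, gives 223 nM; 91 nM (2 entries) in this assay.
Compound 3, `CN1CC(C#Cc2c(Cl)c3c(Cl)cc(C(N)=O)nc3n2[C@H]2CCCNC2)CC1=O`, gives 155 nM in this assay.

Within the data shown here, all three share the same core, carrying an alkyne that ends in a small saturated ring; only that ring differs. Among the measured compounds shown here, compound 3 carries a 1-methyl-5-oxopyrrolidin-3-yl ring there, and its single number sits among those of compound 1 and compound 2, for which the several entries of compound 1 in this assay, 77 nM; 203 nM (2 entries) and the several entries of compound 2 in this assay, 223 nM; 91 nM (2 entries) show how much repeated readings of the same compound can move. Two further readings of compound 3 gave no single number.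

Compound 4, `NC(=O)c1cc(Cl)c2c(Cl)c(C#CC3CCOCC3)n([C@H]3CCCNC3)c2n1`, has not yet been measured. The change from compound 3 is oxan-4-yl in place of 1-methyl-5-oxopyrrolidin-3-yl on a triple-bonded carbon. The entering oxan-4-yl ring resembles the oxygen-containing rings of compound 1 and compound 2, whose values lie within the scatter of compound 3, so no step beyond the scatter is expected in this assay. Compound 4 is therefore expected at 130 nM, with a likely range from 50 nM to 350 nM, a step of a 1.2-fold lower number from compound 3 to compound 4 (0.08 log units; within the scatter).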

Compound 4, half-maximal effective concentration: 69 nM
Compound 4: middle estimate off by 1.9-fold (0.28 log units), on the high side; the measured number falls inside the stated range.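

Among these compounds, this is the first readable step at this position: on the triple-bonded carbon, oxan-4-yl in place of 1-methyl-5-oxopyrrolidin-3-yl gives a 2.2-fold lower number from compound 3 to compound 4 (0.35 log units; beyond the scatter) in this assay. The ring at the end of the alkyne can therefore shift the number, although the step is modest and rests on one number for each compound. Repeated readings of a single compound can differ by a similar amount, so the step needs confirming: the several entries of compound 1 in this assay, 77 nM; 203 nM (2 entries).

The change alters ring size and removes the ring nitrogen and the carbonyl all at once, so the compounds shown do not reveal which of these matters. From the compounds shown here alone, how a piperidine ring with a free amine, a carboxylic acid or an open alkyl chain would behave in this place also remains open.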